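Hydroxymethyl to 1-hydroxyethyl on the shared core of compound 1

The compounds below may be only part of what the source reports. "The series", "measured", "known", "first", "only" and "open" are said of these compounds alone.

Compound 1, `O=C(CN(c1ncnc2c1ncn2C1CCCCO1)C1CC1)N[C@@H](CO)C(=O)OCc1ccccc1`, gives 46.7% in a functional assay on the whole organism (Tail, strain ICR) with Mus musculus as the target, in the tail flick test, with a stated time of 60 min, at a dose of 25 umol/kg by the oral route; a higher number here means a stronger effect of the compound at the dose given, a lower number a weaker effect.
Compound 2, `CC(C)[C@H](NC(=O)CN(c1nc(Cl)nc2[nH]cnc12)C1CC1)C(=O)O`, gives 38.8% in this assay.
Compound 3, `NC(=O)C[C@H](NC(=O)CN(c1nc(Cl)nc2[nH]cnc12)C1CC1)C(=O)O`, gives 43.1% in this assay.

Of the three numbers, that of compound 1 is the largest on its face, but its distances to compound 3 and to compound 2 both fall within the usual scatter, so the three compounds cannot be ranked on these data. Going by the values given here, the only step among measured pairs is a number 4.3 percentage points higher from compound 2 to compound 3 (within the scatter), and it sits on a different core and at a different place from the change now in question, so it offers no direct guide.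

Compound 4, `C[C@@H](O)[C@H](NC(=O)CN(c1ncnc2c1ncn2C1CCCCO1)C1CC1)C(=O)OCc1ccccc1`, is not yet measured. It differs from compound 1 by methyl in place of hydrogen on a saturated chain carbon bound to an oxygen on a saturated carbon and a saturated chain carbon.

Among the compounds with values here, since no measured step touches this change, the expectation rests on compound 1 alone, whose 46.7% is taken as the starting point. The step of a number 1.7 percentage points lower from compound 1 to compound 4 (within the scatter) is expected to stay within the usual scatter, with no direction favoured. Compound 4 is therefore estimated at 45%, within a range from 30% to 60%.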

Compound 4, a percentage reported as activity, at one dose (the size of the read-out at that dose, not a potency): 28.4%
For compound 4 the middle estimate is 16.6 percentage points above the measured one; measured number outside the range, below it.
By their numbers in this assay, from the lowest: compound 4; then compounds 2, 3 and 1 (each within the scatter of the next).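

Adding one methyl, which turns hydroxymethyl into 1-hydroxyethyl, gives the only step shown that lies beyond the scatter in this assay: a number 18.3 percentage points lower from compound 1 to compound 4 (beyond the scatter), while the hydroxyl stays in place in both compounds. Going by these compounds alone, this shows that the read-out at this dose responds to a single added carbon on this saturated chain carbon, something the earlier numbers could not reveal, as the one earlier step, a number 4.3 percentage points higher from compound 2 to compound 3 (within the scatter), sits on a different core and stays within the scatter despite exchanging isopropyl for carbamoylmethyl. No measurement shown here bears on why the number falls with this change.

From the compounds shown here alone, it remains open whether a longer chain such as 1-hydroxypropyl, or an amine in place of the hydroxyl on this carbon, would give a number nearer to that of compound 1 or to that of compound 4. Going by these compounds, it is also open whether the same methyl would lower the number on the core of compound 2 and compound 3, which carries a free carboxylic acid instead of the benzyl ester, as this single pair is all that speaks for the change.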